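Hexyl to Phenyl on the Urea of Compound 1

The source may report more compounds than this note shows. Statements on the series, on what has been measured and on what is new or still open speak of the compounds shown alone.

Measured compounds:
compound 1 `CCCCCCNC(=O)/N=C(\N)NCCCc1sc(N)nc1C` — 38.9 nM
compound 2 `Cc1nc(N)sc1CCCN/C(N)=N/C(=O)NCC(C)CC1CCCCC1` — 17.4 nM

Going by the values given here, in a functional assay on membranes from Sf9 cells for agonist activity at histamine H2 receptor (Homo sapiens), read by scintillation counting and GTPgammaS binding, with a stated time of 90 min (on this read-out higher numbers stand for an effect only at larger amounts of compound and lower numbers for an effect already at smaller amounts), compound 1 gives 38.9 nM, the higher of the two numbers measured so far. Its nearest neighbour is compound 2, which differs only at the end of the urea chain, and the step of a 2.2-fold lower number from compound 1 to compound 2 (0.35 log units; beyond the scatter) shows that a branched, ring-bearing chain gave a somewhat lower number.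

Compound 3 `Cc1nc(N)sc1CCCN/C(N)=N/C(=O)Nc1ccccc1` is not yet measured. It differs from compound 1 by phenyl in place of hexyl on an amide-type nitrogen. Among the compounds with values here, only the single step from compound 1 to compound 2 bears on this, and it swapped one saturated chain for another; no measured pair here exchanges a saturated chain for an aromatic ring, so that step speaks only loosely to compound 3. Given one step of modest size in one direction, the expectation for compound 3 in this assay is a number near that of compound 1, with a wide range: the estimate is 45 nM, between 12 nM and 170 nM, which corresponds to an expected step of a 1.2-fold higher number from compound 1 to compound 3 (0.06 log units; within the scatter).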

Compound 3, half-maximal effective concentration: 525 nM
Estimate against measurement, compound 3: 12-fold (1.07 log units) below; measured number outside the range, above it.
By their numbers in this assay, from the lowest: compound 2; then compound 1; then compound 3.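

Hexyl and phenyl have the same count of heavy atoms, all carbon, yet putting phenyl in place of hexyl on the amide-type nitrogen gives, in this assay, a 13-fold higher number from compound 1 to compound 3 (1.13 log units; beyond the scatter), so the atom count of this group does not set the result. The earlier step, a 2.2-fold lower number from compound 1 to compound 2 (0.35 log units; beyond the scatter), exchanged one saturated chain for another and moved the number far less, which shows that this position accepts some change in a saturated chain but reacts strongly when an aromatic ring sits directly on the nitrogen. Nothing in the available data accounts for the size of this rise.

On these data alone, what remains open is whether the aromatic character of the ring matters, or whether the loss comes from having any ring directly on the nitrogen, since the 1-(cyclohexylmethyl)ethyl group of compound 2 carries its ring further out along a chain. A cyclohexyl group on the same nitrogen would separate those two readings, while benzyl or 2-phenylethyl would show whether an aromatic ring held further out on a chain fares better.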